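This account rests on a few compounds, and the source may have more. Where it says the series, first, only, none or still open, it means among the compounds named here.

Measured compounds:
compound 1 `O=C(Cn1c(=O)oc2cc(Cl)ccc21)NCc1cccs1` gives 20.3%
compound 2 `O=C(Cn1c(=O)oc2cc(Cl)ccc21)Nc1ccccc1` gives 15.8%
compound 3 `O=C(Cn1c(=O)oc2ccccc21)NCc1cccs1` gives 23.4%

These three values come from an ADME assay on RAW264.7 cells (Mus musculus) for cytotoxicity, read by MTT assay, with a stated time of 72 h, tested at 50 uM; on this read-out higher numbers stand for a stronger effect at the one concentration tested and lower numbers for a weaker effect. Among the measured compounds shown here, all three numbers lie within the scatter of one another, so no compound can be ranked against the others. Compound 2 differs from compound 1 by phenyl in place of (thiophen-2-yl)methyl on an amide-type nitrogen, and this step is a number 4.5 percentage points lower from compound 1 to compound 2 (within the scatter). Compound 3 differs from compound 1 by hydrogen in place of chloro on an aromatic carbon, and this step is a number 3.1 percentage points higher from compound 1 to compound 3 (within the scatter).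

Compound 4 `O=C(Cn1c(=O)oc2ccccc21)Nc1ccccc1` has not yet been measured in this assay. It differs from compound 3 by phenyl in place of (thiophen-2-yl)methyl on an amide-type nitrogen, the same change that led from compound 1 to compound 2, here made on the core of compound 3. Since that change earlier gave a number 4.5 percentage points lower from compound 1 to compound 2 (within the scatter), the step from compound 3 to compound 4 is expected to be similar, namely a number 4.4 percentage points lower from compound 3 to compound 4 (within the scatter). On this basis compound 4 is estimated to give 19% in this assay, with a range from 10% to 28%. The measurement will show whether this holds.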

Compound 4, a percentage reported as inhibition, at one concentration (the size of the read-out at that concentration, not a potency): 35.1%
Estimate against measurement, compound 4: 16.1 percentage points below, and the stated range ends below it.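

In this assay, phenyl in place of (thiophen-2-yl)methyl on the amide-type nitrogen gave a number 11.7 percentage points higher from compound 3 to compound 4 (beyond the scatter) on the core of compound 3, and this change did not carry over unchanged between the two cores: the same change on two cores in this assay, a number 4.5 percentage points lower (within the scatter) from compound 1 to compound 2 and a number 11.7 percentage points higher (beyond the scatter) from compound 3 to compound 4, 16.2 percentage points apart, beyond the scatter of two such steps

Read the other way, hydrogen in place of chloro gave a number 19.3 percentage points higher from compound 2 to compound 4 (beyond the scatter) with phenyl on the amide-type nitrogen, and this step did not match the one seen with (thiophen-2-yl)methyl there: the same change on two cores in this assay, a number 3.1 percentage points higher (within the scatter) from compound 1 to compound 3 and a number 19.3 percentage points higher (beyond the scatter) from compound 2 to compound 4, 16.2 percentage points apart, beyond the scatter of two such steps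

Both comparisons rest on the same four compounds, so they show a single case in which the two changes do not add up independently, and they give neither a cause nor a rule for other groups.

The compounds shown leave open how a benzyl group or a longer alkyl chain on the amide-type nitrogen would behave on either core. They also leave open whether fluoro or methoxy in place of chloro would show the same dependence on the group at that nitrogen.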